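Bromo to methoxy on the aryl group of compound 3

This account rests on a few compounds, and the source may have more. Where it says the series, first, only, none or still open, it means among the compounds named here.

Values in a functional assay on HepG2 cells (Homo sapiens) for inhibition, read by MTT assay, with a stated time of 72 h (on this read-out higher numbers stand for weaker inhibition and lower numbers for stronger inhibition), for the measured compounds
compound 1 `Cc1ccc(-c2cc(C(=O)N3CCC4(CC3)CC(=O)c3nn(C(C)(C)C)cc3O4)c3ccccc3n2)cc1` gives 1440 nM
compound 2 `CC(C)(C)n1cc2c(n1)C(=O)CC1(CCN(C(=O)c3cc(-c4ccc(F)cc4)nc4ccccc34)CC1)O2` gives 2930 nM
compound 3 `CC(C)(C)n1cc2c(n1)C(=O)CC1(CCN(C(=O)c3cc(-c4ccc(Br)cc4)nc4ccccc34)CC1)O2` gives 820 nM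

In this assay, among the compounds with values here, compound 3 stands clearly apart from only one of its two neighbours. The modest 3.6-fold lower number from compound 2 to compound 3 (0.55 log units; beyond the scatter) lies beyond the scatter, while a 1.8-fold lower number from compound 1 to compound 3 (0.24 log units; within the scatter) stays within it. The unmeasured compound 4 `COc1ccc(-c2cc(C(=O)N3CCC4(CC3)CC(=O)c3nn(C(C)(C)C)cc3O4)c3ccccc3n2)cc1` has methoxy in place of bromo on an aromatic carbon, para to a large group (methoxy in place of bromo on an aromatic carbon).

Within the data shown here, no measured step involves methoxy, so the evidence is indirect. The other swaps at this place are a 2.0-fold higher number from compound 1 to compound 2 (0.31 log units; beyond the scatter) and the two steps above, and all of them are modest or smaller. A step of similar size is therefore expected, and a small rise seems the likelier direction, since the step to the fluoro compound 2 is the only clear separation from bromo. The expected change is a 1.7-fold higher number from compound 3 to compound 4 (0.23 log units; within the scatter), which would be no clear shift. For compound 4 the estimated value is 1400 nM, with an expected range of 650 nM to 3000 nM.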

Compound 4, half-maximal inhibitory concentration: 2780 nM
Beside the measured number, compound 4's estimate is 2.0-fold (0.30 log units) below it; the range from low to high includes it.
By their numbers in this assay, from the lowest: compounds 3, 1, 4 and 2 (each within the scatter of the next, the first and the last beyond it).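

In this assay, replacing bromo with methoxy on the aromatic carbon gives a 3.4-fold higher number from compound 3 to compound 4 (0.53 log units; beyond the scatter), so compound 3 now stands clearly apart from two of the three other compounds, not one. The methoxy and fluoro compounds cannot be told apart, with a 1.1-fold lower number from compound 2 to compound 4 (0.02 log units; within the scatter), and neither can the methoxy and methyl compounds, with a 1.9-fold higher number from compound 1 to compound 4 (0.29 log units; within the scatter), which leaves compound 1 within the scatter of compound 3 and compound 4 and beyond it only from compound 2. Nothing available explains why bromo separates from methoxy and fluoro here.

The compounds shown leave open whether chloro or iodo at this place would read like bromo. They also leave open how a hydroxy group or an amine on the same aromatic carbon would read in this assay.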